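Adding a second chloro to compound 3

The compounds below may be only part of what the source reports. "The series", "measured", "known", "first", "only" and "open" are said of these compounds alone.

Measured in a functional assay on HepG2 cells (Homo sapiens) for antiproliferative activity, read by MTT assay, with a stated time of 72 h; a higher number here means a weaker inhibitor, a lower number a stronger inhibitor:
Compound 1 `COc1cc(CCc2ccccc2)cc(OC)c1O` gives 7830 nM
Compound 2 `COc1cc(CCc2ccccc2Cl)cc(OC)c1O` gives 2190 nM
Compound 3 `COc1cc(CCc2ccc(Cl)cc2)cc(OC)c1O` gives 8780 nM

The step of a 1.1-fold higher number from compound 1 to compound 3 (0.05 log units; within the scatter) stays within the scatter. Compound 3 thus stands level with compound 1, and compound 2 shows a lower number than either. Compound 4 `COc1cc(CCc2ccc(Cl)cc2Cl)cc(OC)c1O` follows from compound 3 through chloro in place of hydrogen on an aromatic carbon and the new chloro sits ortho to a large group and meta to a chloro group. For the measured compounds named here, the nearest precedent is a 3.6-fold lower number from compound 1 to compound 2 (0.55 log units; beyond the scatter) with the chloro at that same place on the ring. A modest lower number of similar size is therefore expected, an estimated 3.5-fold lower number from compound 3 to compound 4 (0.55 log units; beyond the scatter) in this assay and beyond the scatter. For compound 4 the estimated value is 2500 nM with an expected range from 1000 nM to 6000 nM.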

Compound 4, half-maximal inhibitory concentration: 6740 nM
Estimate against measurement, compound 4: 2.7-fold (0.43 log units) below; the measured number lies above the stated range.
By their numbers in this assay, from the lowest: compound 2; then compounds 4, 1 and 3 (each within the scatter of the next).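

In this assay, the chloro ortho to a large group brings only a 1.3-fold lower number from compound 3 to compound 4 (0.11 log units; within the scatter), so the step seen on the core of compound 1 does not carry over to a core that already holds a chloro group meta to it: the same change on two cores in this assay, a 3.6-fold lower number (0.55 log units; beyond the scatter) from compound 1 to compound 2 and a 1.3-fold lower number (0.11 log units; within the scatter) from compound 3 to compound 4, 2.7-fold (0.44 log units) apart, beyond the scatter of two such steps Seen from compound 2, the other chloro of compound 4 gives a 3.1-fold higher number from compound 2 to compound 4 (0.49 log units; beyond the scatter), although the same change left compound 1 within the scatter: the same change on two cores in this assay, a 1.1-fold higher number (0.05 log units; within the scatter) from compound 1 to compound 3 and a 3.1-fold higher number (0.49 log units; beyond the scatter) from compound 2 to compound 4, 2.7-fold (0.44 log units) apart, beyond the scatter of two such steps In these four compounds, the two chloro groups therefore do not add up.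

The compounds shown leave open whether a fluoro or an amine at this place would follow the chloro on both cores.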